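Swapping the carboxy group of compound 1 for hydroxymethyl

The compounds below may be only part of what the source reports. "The series", "measured", "known", "first", "only" and "open" are said of these compounds alone.

Compound 1 `C=CC(=O)Nc1ccc(Cn2nc(-c3ccc(Oc4ccccc4)cc3)cc2C(=O)O)cc1` was examined in a functional assay on Rec1 cells (Homo sapiens) for inhibition, read by luminescence and CellTiter-Glo, with a stated time of 72 h; on this read-out higher numbers stand for weaker inhibition and lower numbers for stronger inhibition. Compound 1 stands at > 60000 nM, and this is a limit of the assay, not a number.

Compound 2 `C/C=C/C(=O)Nc1ccc(Cn2nc(-c3ccc(Oc4ccccc4)cc3)cc2C(=O)O)cc1` has prop-1-en-1-yl in place of vinyl on a carbonyl carbon. In this assay compound 2 gives 23600 nM, and the measured change is an at least 2.5-fold lower number from compound 1 to compound 2 (0.40 log units; beyond the scatter). Compound 3 `C/C=C/C(=O)N1CCCC(n2nc(-c3ccc(Oc4ccccc4)cc3)cc2C(=O)OCC)C1` differs from compound 1 in more than one place and carries an ethyl ester instead of a free carboxy group. In this assay compound 3 gives 5100 nM.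

Compound 4 `C=CC(=O)Nc1ccc(Cn2nc(-c3ccc(Oc4ccccc4)cc3)cc2CO)cc1` keeps the vinyl carbonyl of compound 1 and changes a different place: hydroxymethyl in place of carboxy on an aromatic carbon. In words, hydroxymethyl stands in place of carboxy on an aromatic carbon. Within the data shown here, no measured step isolates a change at this place, and the one clean step, from vinyl to prop-1-en-1-yl, lies elsewhere in the molecule. Among the measured compounds shown here, the only guide is compound 3, which lacks the free carboxy group and reads 5100 nM, so a clear move towards lower numbers is expected, though its size is poorly constrained. The expected change is an at least 7.5-fold lower number from compound 1 to compound 4 (0.87 log units; beyond the scatter). For compound 4 the estimate is 8000 nM, with an expected range of 1500 nM to 40000 nM.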

Compound 4, half-maximal inhibitory concentration: 3500 nM
Compound 4: the middle estimate sits 2.3-fold (0.36 log units) above what was measured, within the range that was stated.
By their numbers in this assay, from the lowest: compounds 4 and 3 (each within the scatter of the next); then compound 2. At a limit, above all of these: compound 1.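

Hydroxymethyl in place of carboxy on an aromatic carbon gives an at least 17-fold lower number from compound 1 to compound 4 (1.23 log units; beyond the scatter) in this assay, and this is the first measured step at this place. Compound 3 also lacks the free carboxy group, but it differs from compound 1 in more than one place, so it could not tie any shift to this position; here the vinyl carbonyl and the rest of the molecule stay as they are, and the large step belongs to the exchange of carboxy for hydroxymethyl alone. The value of compound 1 is a limit and not a number, so this step has a lower bound and no fixed size: the limit of > 60000 nM in this assay, at which 1 of the 4 values shown sits.

Going by these compounds, what remains open is whether the step depends on hydroxymethyl in particular or would also follow from another group at this place, such as a primary amide, a methyl ether or an aminomethyl group. Also open, on these data alone, is how hydroxymethyl at this place would read in this assay alongside prop-1-en-1-yl on the carbonyl carbon, and whether the two single steps would add up in one molecule.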